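Benzamide variation on the shared core: no readable signal yet

The source may hold more compounds than are shown below. What is called first, only, known or untested is meant among the compounds shown, and "the series" means these compounds.

Measured in an assay for inhibition of HSP60/HSP10 (Homo sapiens), with a stated time of 60 min; on this read-out lower numbers stand for stronger inhibition and higher numbers for weaker inhibition:
compound 1, `COc1c(Br)cccc1C(=O)Nc1ccc(Sc2nc3ccccc3s2)c(Cl)c1`, a limit of the assay only: > 100000 nM
compound 2, `O=C(Nc1ccc(Sc2nc3ccccc3s2)c(Cl)c1)c1cccc(Br)c1`, a limit of the assay only: > 100000 nM
compound 3, `COc1c(Br)cc(Br)cc1C(=O)Nc1ccc(Sc2nc3ccccc3s2)c(Cl)c1`, a limit of the assay only: > 100000 nM

Compound 3 stands at a limit and not at a number. Among the measured compounds shown here, the two further values shown are limits as well, so every value so far sits at the limit of > 100000 nM in this assay, at which 3 of the 3 values shown sit. The steps a step that the two limits leave unreadable from compound 1 to compound 2, a step that the two limits leave unreadable from compound 1 to compound 3 and a step that the two limits leave unreadable from compound 2 to compound 3 are therefore all unreadable in size; no direction can be taken from them.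

Compound 4, `O=C(Nc1ccc(Sc2nc3ccccc3s2)c(Cl)c1)c1ccccc1`, is to be measured in this assay. It differs from compound 3 in a group of 6 heavy atoms (6 carbon; one six-membered aromatic ring of carbon only) in place of a group of 10 heavy atoms (7 carbon, 1 oxygen, 2 bromine; one six-membered aromatic ring of carbon only), on a carbonyl carbon. For the measured compounds named here, the only measured step at the same carbonyl carbon is a step that the two limits leave unreadable from compound 2 to compound 3, and it gives no size. With three limits and no readable step, the expected outcome for compound 4 is a further limit rather than a number. Compound 4 is estimated at 100000 nM, with a range from 30000 nM to 300000 nM. The step this expectation implies is a number no higher from compound 3 to compound 4 (the limit leaves the size open).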

Compound 4, half-maximal inhibitory concentration: > 100000 nM
Compound 4: only a limit was reported; the forecaster's own chance of this, stated with the estimate: 85%; the middle value lies on the limit itself.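

Compound 4 gives > 100000 nM, a limit of the assay and not a number. Its steps from compound 1, compound 2 and compound 3 therefore cannot be read, and every value remains at a limit: the limit of > 100000 nM in this assay, at which 4 of the 4 values shown sit.

Still open, as far as these compounds go, is which group on the carbonyl carbon, if any, gives a number in this assay.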